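A few compounds are considered here, and "the series" means these few. Any claim that something is new, unique, unknown or untested is made for them only; others in the source may bear on it.

Compound 1 `Cc1ncc(-c2nc(C(F)(F)F)sc2N2CCN(C(=O)Cn3cnc4cccnc43)[C@H](C)C2)cn1`: 168 nM
Compound 2 `CCOc1ncc(-c2nc(C(F)(F)F)sc2N2CCN(C(=O)Cn3ccc4cnccc43)[C@H](C)C2)cn1`: 23 nM
Compound 3 `Cc1ncc(-c2nc(C(F)(F)F)sc2N2CCN(C(=O)Cn3nc(C)nc3C)[C@H](C)C2)cn1`: 578 nM

In a functional assay on U2OS cells for antagonist activity at C-X-C chemokine receptor type 3 (Homo sapiens), read by beta-arrestin recruitment (on this read-out higher numbers stand for weaker inhibition and lower numbers for stronger inhibition), compound 3 stands highest of the three numbers; compound 1 is its nearest neighbour, and the step of a 3.4-fold higher number from compound 1 to compound 3 (0.54 log units; beyond the scatter) separates them, while compound 2 lies furthest away with a much lower number.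

Compound 4 `Cc1nc(C)n(CC(=O)N2CCN(c3sc(C(F)(F)F)nc3-c3cnc(N4CCCC4)nc3)C[C@H]2C)n1` changes a different part of the molecule: pyrrolidin-1-yl in place of methyl on an aromatic carbon. For the measured compounds named here, none of the measured steps alters this position alone, and compound 2, which carries a different group there, also differs in the chain group, so its lower number cannot be credited to one change. Without a direct precedent, the expected step of a 1.4-fold lower number from compound 3 to compound 4 (0.16 log units; within the scatter) in this assay is small and of uncertain direction. Compound 4 is therefore estimated at 400 nM, within 120 nM to 1500 nM.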

Compound 4, half-maximal inhibitory concentration: 523 nM
Estimate against measurement, compound 4: 1.3-fold (0.12 log units) below; measured number inside the range.
By their numbers in this assay, from the lowest: compound 2; then compound 1; then compounds 4 and 3 (each within the scatter of the next).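

In this assay the first direct test of this position, with the rest of the molecule held fixed, gives a 1.1-fold lower number from compound 3 to compound 4 (0.04 log units; within the scatter) for pyrrolidin-1-yl in place of methyl. The position therefore accepts a ring-bearing amine here without a measurable change in the number. Nothing available explains this result.

As far as these compounds go, it remains open whether pyrrolidin-1-yl would behave the same with the chain group of compound 1 or compound 2. From the compounds shown here alone, it is also open how a morpholin-4-yl ring or a carboxylic acid would fare at this position.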